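This account rests on a few compounds, and the source may have more. Where it says the series, first, only, none or still open, it means among the compounds named here.

Compound 2 `CNCc1ccc(Cl)c(-c2ccccc2OC)c1` is the weaker of the two measured compounds: in an assay on isolated protein for binding affinity to 5-hydroxytryptamine receptor 1D (Homo sapiens) (a higher number here means a weaker inhibitor, a lower number a stronger inhibitor), compound 2 gives 1200 nM, the highest number in the set, against 19 nM for compound 1 `COc1ccccc1-c1cc(C2CCN(C)C2)ccc1Cl`. Among the measured compounds shown here, the one measured step, a 63-fold higher number from compound 1 to compound 2 (1.80 log units; beyond the scatter), replaces the ring-bound amine of compound 1 by an open-chain amine.

Compound 3 `CCNCc1ccc(Cl)c(-c2ccccc2OC)c1` follows from compound 2 by methyl in place of hydrogen on a saturated chain carbon bound to an amine nitrogen. For the measured compounds named here, no measured step touches this carbon; the step from compound 1 to compound 2 alters the amine part as a whole and does not bear on a single methyl added there. The change is small and leaves donor and acceptor counts unchanged, so the expected step in this assay for compound 3 is a 1.2-fold lower number from compound 2 to compound 3 (0.08 log units; within the scatter), not clearly beyond the scatter in either direction. Compound 3 is therefore estimated at 1000 nM, with a range of 350 nM to 3000 nM.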

Compound 3, inhibition constant: 220 nM
The estimate for compound 3 lay 4.5-fold (0.66 log units) above the measured number; measured number below the stated range.
By their numbers in this assay, from the lowest: compound 1; then compound 3; then compound 2.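

In this assay the saturated chain carbon bound to an amine nitrogen is not a silent position: going from methylamino to ethylamino gives a 5.5-fold lower number from compound 2 to compound 3 (0.74 log units; beyond the scatter) with one added methyl alone. The open-chain amine still stays short of the ring-bound amine, with a 12-fold higher number from compound 1 to compound 3 (1.06 log units; beyond the scatter) against a 63-fold higher number from compound 1 to compound 2 (1.80 log units; beyond the scatter) for the methylamino compound, so the ethylamino group closes only part of that gap. No measurement at hand gives a reason for the gain at this carbon.

The open-chain amines shown stop at methylamino and ethylamino, and whether propylamino or isopropylamino extends the step remains open. Also open, going by these compounds, is whether a dimethylamino group in the same place keeps the step.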